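Chloro for Acetyl on a Urea Core: Solubility Outlook

The compounds below may be only part of what the source reports. "The series", "measured", "known", "first", "only" and "open" are said of these compounds alone.

Compound 1 `CC(=O)c1ccc(NC(=O)Nc2cc(C)nc3ccccc23)cc1` gives 3800 nM in a physicochemical assay for solubility, at pH 7.4; a higher number here means a more soluble compound, a lower number a less soluble compound.
Compound 2 `Cc1cc(NC(=O)Nc2cccc3nsnc23)c2ccccc2n1` gives 300 nM in this assay.
Compound 3 `COc1cccc(NC(=O)Nc2cc(C)nc3ccccc23)c1` gives 1200 nM in this assay.

Compound 1 stands highest of the three numbers; compound 3 comes nearest, and compound 2 lies furthest below it, both gaps beyond the usual scatter. Compound 4 `Cc1cc(NC(=O)Nc2ccc(Cl)cc2)c2ccccc2n1` has not been measured. It differs from compound 1 in one place: chloro in place of acetyl on an aromatic carbon. Among the compounds with values here, no step between measured compounds matches this change, so the expectation rests on compound 1 alone, whose value 3800 nM is the starting point. A moderate step downward, beyond the scatter, is expected: a 4.2-fold lower number from compound 1 to compound 4 (0.63 log units; beyond the scatter). Compound 4 is therefore estimated at 900 nM, within a range from 300 nM to 2700 nM.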

Compound 4, solubility: 1400 nM
Compound 4: middle estimate off by 1.6-fold (0.19 log units), on the low side; the measured number falls inside the stated range.
By their numbers in this assay, from the lowest: compound 2; then compounds 3 and 4 (each within the scatter of the next); then compound 1.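

In this assay, chloro in place of acetyl on an aromatic carbon para to a large group gives a 2.7-fold lower number from compound 1 to compound 4 (0.43 log units; beyond the scatter) in a modest step, the first single-place step available at this position. It shows that this one change on the shared core is enough to move the number beyond the scatter. No measured evidence bears on why the step occurs. Going by these compounds, whether an amine or a carboxylic acid at this position would give a higher or lower number than acetyl remains open. So does whether the same change gives a similar step on another core.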